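From 2-methoxyphenyl to 2-fluorophenyl in the series

The source may hold more compounds than are shown below. What is called first, only, known or untested is meant among the compounds shown, and "the series" means these compounds.

For the measured compounds named here, in an ADME assay on the whole organism (Rattus norvegicus, strain Sprague-Dawley) for pharmacokinetics, read by LC-MS, with a stated time of 10 min (on this read-out higher numbers stand for wider distribution into tissues and lower numbers for narrower distribution), two compounds have numbers so far. Compound 1 (`Cc1ccccc1-c1cccc(-c2cc3nc(C)c([C@H](OC(C)(C)C)C(=O)O)c(-c4cc(F)c5c(c4C)CCCO5)n3n2)c1`) gives 0.5 L/kg, and compound 2 (`COc1ccccc1-c1cccc(-c2cc3nc(C)c([C@H](OC(C)(C)C)C(=O)O)c(-c4cc(F)c5c(c4C)CCCO5)n3n2)c1`) gives 1.8 L/kg, the higher of the two numbers. Going by the values given here, the single measured step, a 3.6-fold higher number from compound 1 to compound 2 (0.56 log units; beyond the scatter), is modest but beyond the scatter, and comes with methoxy in place of methyl on an aromatic carbon.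

Next is compound 3 (`Cc1nc2cc(-c3cccc(-c4ccccc4F)c3)nn2c(-c2cc(F)c3c(c2C)CCCO3)c1[C@H](OC(C)(C)C)C(=O)O`), with fluoro in place of methoxy on an aromatic carbon, ortho to a large group: fluoro in place of methoxy on an aromatic carbon. Among the compounds with values here, the methoxy group leaves from the place where the measured step introduced it, so that step, a 3.6-fold higher number from compound 1 to compound 2 (0.56 log units; beyond the scatter), is the only guide. Within the data shown here, no fluoro compound has a number yet, which leaves the size of the new step uncertain. A fall in this assay is expected, of similar or smaller size than the measured step, with a partial return towards compound 1 at 0.5 L/kg.

The expected step is a 2.3-fold lower number from compound 2 to compound 3 (0.35 log units; beyond the scatter). For compound 3 the estimated value is 0.8 L/kg, with an expected range of 0.4 L/kg to 1.7 L/kg.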

Compound 3, volume of distribution at steady state: 0.7 L/kg
Compound 3: the middle estimate sits 1.1-fold (0.06 log units) above what was measured; measured number inside the range.
By their numbers in this assay, from the lowest: compounds 1 and 3 (each within the scatter of the next); then compound 2.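

In this assay, fluoro on this aromatic carbon, ortho to a large group, does not hold what methoxy gave, the swap giving a 2.6-fold lower number from compound 2 to compound 3 (0.41 log units; beyond the scatter). Set against methyl at the same place, fluoro gives a 1.4-fold higher number from compound 1 to compound 3 (0.15 log units; within the scatter), so these two groups cannot be told apart on this read-out, and of the three groups read here, methoxy alone stands apart, with compound 2 at 1.8 L/kg. No measurement at hand speaks to what lies behind that difference.

Still open, from the compounds shown here alone, is whether the higher number belongs to methoxy alone or also appears with other groups at this place, such as ethoxy, hydroxyl or an amine, which would show whether the oxygen-bearing substituent is the common thread or methoxy is a single case. Going by these compounds, all three compounds also share the rest of the structure, so whether the same reading of methyl, methoxy and fluoro carries over to a different core remains unknown.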